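A few compounds are considered here, and "the series" means these few. Any claim that something is new, unique, unknown or untested is made for them only; others in the source may bear on it.

Measured compounds in a functional assay on SK-BR-3 cells (Homo sapiens) for antiproliferative activity, read by XTT assay, with a stated time of 72 h; on this read-out higher numbers stand for weaker inhibition and lower numbers for stronger inhibition:
Compound 1 `COc1ccc(-c2cc3ccccc3nc2C=O)cc1`: > 10000 nM, which is a limit of the assay rather than a number.
Compound 2 `COc1ccc(-c2cc3ccccc3nc2/C=C/C(=O)c2ccccc2)cc1`: 700 nM.
Compound 3 `COc1ccc(-c2cc3ccccc3nc2/C=C/C(=O)c2ccc(OC)c(OC)c2)cc1`: 3260 nM.

Compound 3 stands highest of the two numbers in this assay; its nearest neighbour is compound 2, and the step of a 4.7-fold higher number from compound 2 to compound 3 (0.67 log units; beyond the scatter) lies beyond the scatter. Compound 4 `COc1ccc(-c2cc3ccccc3nc2/C=C/C(=O)c2ccccn2)cc1` has not yet been measured in this assay. It differs from compound 3 in one place: pyridin-2-yl in place of 3,4-dimethoxyphenyl on a carbonyl carbon. Going by the values given here, only one measured step bears on this position, the replacement of phenyl by 3,4-dimethoxyphenyl on the same carbonyl carbon, a 4.7-fold higher number from compound 2 to compound 3 (0.67 log units; beyond the scatter), a modest rise. The ring that enters in compound 4 is smaller than the ring that leaves, as pyridin-2-yl in place of 3,4-dimethoxyphenyl on a carbonyl carbon shows, so the change runs partly back toward what compound 2 carries. Compound 4 is therefore expected to give a lower number than compound 3, by about a 2.7-fold lower number from compound 3 to compound 4 (0.43 log units; beyond the scatter), though direction is less certain than size. The estimate for compound 4 in this assay is 1200 nM, with a range from 400 nM to 4000 nM.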

Compound 4, half-maximal inhibitory concentration: 370 nM
The estimate for compound 4 lay 3.2-fold (0.51 log units) above the measured number, and the stated range ends above it.
By their numbers in this assay, from the lowest: compounds 4 and 2 (each within the scatter of the next); then compound 3. At a limit, above all of these: compound 1.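

In this assay, going by these compounds alone, the earlier compounds showed only a loss at this position, but the group on the carbonyl carbon now moves the number down as well: pyridin-2-yl in place of 3,4-dimethoxyphenyl gives an 8.8-fold lower number from compound 3 to compound 4 (0.95 log units; beyond the scatter), a step beyond the scatter. Set against phenyl, the same group gives a 1.9-fold lower number from compound 2 to compound 4 (0.28 log units; within the scatter), which lies within the scatter, so a ring with a hetero atom can stand here with no change that can be told apart. Among these three groups, 3,4-dimethoxyphenyl alone stands apart from the other two.

Still open, going by these compounds, is whether a single methoxy group would be enough to raise the number, and how an amine or a carboxylic acid on this ring would read. The data shown offer no measured property that accounts for any of these steps.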